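Swapping pyridin-3-yl for 1,2-oxazol-5-yl on a carbonyl carbon

A few compounds are considered here, and "the series" means these few. Any claim that something is new, unique, unknown or untested is made for them only; others in the source may bear on it.

Measured in a toxicity assay on THP-1 cells (Homo sapiens) for inhibition; a higher number here means that more compound is tolerated, a lower number that less compound is tolerated:
Compound 1 `COc1ccc(-c2cnc(NC(=O)c3ncc[nH]3)n2C)cc1`: > 100000 nM
Compound 2 `COc1ccc(-c2cnc(NC(=O)c3cccnc3)n2C)cc1`: > 100000 nM

Both entries are limits of the assay and not numbers. On these data alone, compound 2 has only a limit, > 100000 nM, so its true position is unknown. Compound 3 `COc1ccc(-c2cnc(NC(=O)c3ccno3)n2C)cc1` differs from compound 2 in one place: 1,2-oxazol-5-yl in place of pyridin-3-yl on a carbonyl carbon.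

Within the data shown here, one measured step bears on this change, since it also swaps the ring on a carbonyl carbon: a step that the two limits leave unreadable from compound 1 to compound 2. The evidence for it is the limit of > 100000 nM in this assay, at which 2 of the 2 values shown sit. Given a step that the two limits leave unreadable from compound 1 to compound 2, no step beyond the scatter is expected in this assay, in either direction. The expected step is a number no higher from compound 2 to compound 3 (the limit leaves the size open). Compound 3 is expected at 100000 nM, with an estimated range of 40000 nM to 250000 nM.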

Compound 3, half-maximal cytotoxic concentration: > 100000 nM
Compound 3 ended at the assay's limit; the forecaster's own chance of this, stated with the estimate: 85%; the middle value lies on the limit itself.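

In this assay compound 3 gives only a limit, > 100000 nM, so no step can be read among compound 1, compound 2 and compound 3: the limit of > 100000 nM in this assay, at which 3 of the 3 values shown sit.

The compounds shown leave open how much compound is actually tolerated and whether the ring on the carbonyl carbon makes any difference.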